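Adding a Methoxy Group to a Weak Hydroxamic Acid

A few compounds are considered here, and "the series" means these few. Any claim that something is new, unique, unknown or untested is made for them only; others in the source may bear on it.

Among the compounds with values here, in a functional assay on HL-60 cells (Homo sapiens) for antiproliferative activity, tested at 20 uM (a higher number here means a stronger effect of the compound at the concentration tested, a lower number a weaker effect), compound 2 `Cc1cc2cc(NS(=O)(=O)Cc3ccc(C(=O)NO)cc3)ccc2n(C)c1=O` gives 0%, the lower of the two numbers measured so far. Compound 1 `COC(=O)c1ccc(CS(=O)(=O)Nc2ccc3c(c2)cc(C)c(=O)n3C)cc1` gives 14%, and the drop a number 14 percentage points lower from compound 1 to compound 2 (beyond the scatter) came with hydroxyamino in place of methoxy on a carbonyl carbon. Compound 3 `COc1cc(C(=O)NO)ccc1CS(=O)(=O)Nc1ccc2c(c1)cc(C)c(=O)n2C` differs from compound 2 by methoxy in place of hydrogen on an aromatic carbon. Within the data shown here, the only measured step concerns the carbonyl carbon, not the aromatic ring, so it does not bear on this change, and no step beyond the scatter is expected. Compound 3 is therefore expected to give about 4%, between -8% and 20%. The expected step is a number 4 percentage points higher from compound 2 to compound 3 (within the scatter).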

Compound 3, a percentage reported as inhibition, at one concentration (the size of the read-out at that concentration, not a potency): 0%
Estimate against measurement, compound 3: 4 percentage points above, and the stated range covers the measured number.
By their numbers in this assay, from the lowest: compounds 2 and 3 (each within the scatter of the next); then compound 1.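

In this assay, methoxy in place of hydrogen on this aromatic carbon, ortho to a large group and meta to the hydroxycarbamoyl group, gives no change at the digits printed from compound 2 to compound 3 (within the scatter). Within the data shown here, this is the first measured change on the aromatic ring itself, and at the concentration tested it does not lift the hydroxamic acid off its reading. Nothing measured here explains this result. Still open, from the compounds shown here alone, is whether an amine or a fluorine atom on this carbon would raise the number, and whether methoxy would have any effect on the methyl ester, compound 1.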